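Bromo in Place of Nitro: Expecting Little Change

This account rests on a few compounds, and the source may have more. Where it says the series, first, only, none or still open, it means among the compounds named here.

A small set of compounds was tested in an ADME assay on MCF-10A cells (Homo sapiens) for cytotoxicity, read by MTT assay, with a stated time of 72 h; a lower number here means a stronger inhibitor, a higher number a weaker inhibitor. Compound 1 `COc1cccc(-n2c(-c3coc4cc(C)c(Cl)cc4c3=O)nc(-c3ccccc3)c2-c2ccccc2)c1` and compound 2 `Cc1ccc(-n2c(-c3coc4cc(C)c(Cl)cc4c3=O)nc(-c3ccccc3)c2-c2ccccc2)cc1` belong to the set, yet in this assay compound 1 gives "not determined" (no result reported) and compound 2 gives "not determined" (no result reported). Compound 3 `Cc1cc2occ(-c3nc(-c4ccccc4)c(-c4ccccc4)n3-c3ccc([N+](=O)[O-])cc3)c(=O)c2cc1Cl` was tested, and in this assay compound 3 gives only a limit, > 100000 nM, not a single number. That is the limit of > 100000 nM in this assay, at which 1 of the 3 values shown sits. Compound 4 `Cc1cc2occ(-c3nc(-c4ccccc4)c(-c4ccccc4)n3-c3ccc(Br)cc3)c(=O)c2cc1Cl` differs from compound 3 by bromo in place of nitro on an aromatic carbon. Going by the values given here, no step between two measured compounds exists here, so no measured step size can guide the expectation; the step from compound 3 to compound 4 is expected to stay within the scatter, with compound 4 again likely to reach only the limit. Compound 4 is expected to give about 100000 nM, in the range 30000 nM to 300000 nM, an estimated step of a number no higher from compound 3 to compound 4 (the limit leaves the size open).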

Compound 4, half-maximal inhibitory concentration: > 100000 nM
Compound 4 ended at the assay's limit; the forecaster's own chance of this, stated with the estimate: 70%; the middle value lies on the limit itself.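

Compound 3 and compound 4 both give only a limit in this assay, and no step can be read between them. The compounds shown leave open whether swapping nitro for bromo changes the result at all.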